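Replacing butylamino with phenyl on the sulfonyl sulfur

The source may report more compounds than this note shows. Statements on the series, on what has been measured and on what is new or still open speak of the compounds shown alone.

Compound 1 `CC(C)CS(=O)(=O)N[C@@H](CNC(=O)c1ccc2c(c1)C(=O)N(CCC1CCNCC1)C2)C(=O)O` gives 9 nM
Compound 2 `CCOCCS(=O)(=O)N[C@@H](CNC(=O)c1ccc2c(c1)C(=O)N(CCC1CCNCC1)C2)C(=O)O` gives 8 nM
Compound 3 `CCCCNS(=O)(=O)N[C@@H](CNC(=O)c1ccc2c(c1)C(=O)N(CCC1CCNCC1)C2)C(=O)O` gives 19 nM

In a functional assay for inhibition, with Homo sapiens as the target (a higher number here means a weaker inhibitor, a lower number a stronger inhibitor), compound 3 has the highest number of the three. Compound 4 `O=C(NC[C@H](NS(=O)(=O)c1ccccc1)C(=O)O)c1ccc2c(c1)C(=O)N(CCC1CCNCC1)C2` differs from it by phenyl in place of butylamino on a sulfonyl sulfur. Going by the values given here, two measured steps bear on this change: a 2.1-fold higher number from compound 1 to compound 3 (0.32 log units; beyond the scatter) and a 2.4-fold higher number from compound 2 to compound 3 (0.38 log units; beyond the scatter) (both modest). Among the compounds with values here, each brings in butylamino, so its removal is expected to lower the number, though no measured compound carries phenyl there. The expected result is a modest move, a 1.9-fold lower number from compound 3 to compound 4 (0.28 log units; within the scatter). Compound 4 is estimated at 10 nM within a range of 4 nM to 25 nM.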

Compound 4, half-maximal inhibitory concentration: 8 nM
Beside the measured number, compound 4's estimate is 1.3-fold (0.10 log units) above it; the measured number falls inside the stated range.
By their numbers in this assay, from the lowest: compounds 2, 4 and 1 (each within the scatter of the next); then compound 3.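

In this assay the sulfonyl sulfur proves to carry an aromatic ring as well as a saturated chain: phenyl undoes the loss seen with butylamino (a 2.4-fold lower number from compound 3 to compound 4 (0.38 log units; beyond the scatter)) and sits level with 2-ethoxyethyl (no change at the digits printed from compound 2 to compound 4 (within the scatter)) and isobutyl (a 1.1-fold lower number from compound 1 to compound 4 (0.05 log units; within the scatter)). Of the four groups, butylamino alone stands apart from the rest, and phenyl, with no chain at all, does not separate from the other two. Nothing at hand explains this.

As far as these compounds go, whether a phenyl bearing a methoxy group or a carboxylic acid, or a pyridine ring, would stay level remains open. So does whether methylamino would behave as butylamino does.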